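A few compounds are considered here, and "the series" means these few. Any claim that something is new, unique, unknown or untested is made for them only; others in the source may bear on it.

Measured so far:
- Compound 1, `CCOC(=O)C1=CC(c2ccccc2)C2=C(CC(C)(C)CC2=O)N1`: "not active" (no number reported) in an assay on isolated protein for inhibition of glucose-6-phosphatase catalytic subunit 1 (Homo sapiens), read by inositol phosphate accumulation, with a stated time of 30 min, tested at 100 uM; a higher number here means more inhibition at the concentration tested (going by the name of the read-out), a lower number less inhibition
- Compound 2, `CC1(C)CC(=O)C2=C(C1)NC(C(=O)O)=CC2c1ccc(F)cc1`: 16.8% in this assay

Compound 2 holds the only number shown: in this assay compound 2 gives 16.8%, a modest read-out at the single concentration tested. Among the compounds with values here, compound 1 carries an ethyl ester where compound 2 carries a free acid, and in this assay compound 1 is reported as "not active" (no number reported), with no number attached; no step between these two is counted here.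

Compound 3, `CC1(C)CC(=O)C2=C(C1)NC(C(=O)O)=CC2c1ccccc1`, has not yet been measured. It differs from compound 2 at one point: hydrogen in place of fluoro on an aromatic carbon. The fluorine is the only heavy atom that leaves, and nothing but a hydrogen atom takes its place on the shared core. Such a small change is expected to move this assay little, if at all, beyond the usual scatter, perhaps slightly downward. Compound 3 is therefore estimated at 12%, within 0% to 28%, a step of a number 4.8 percentage points lower from compound 2 to compound 3 (within the scatter) expected to lie within scatter.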

Compound 3, a percentage reported as inhibition, at one concentration (the size of the read-out at that concentration, not a potency): 17.1%
Beside the measured number, compound 3's estimate is 5.1 percentage points below it; measured number inside the range.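

In this assay, replacing fluoro with hydrogen on the aromatic ring, para to a large group, gives a number 0.3 percentage points higher from compound 2 to compound 3 (within the scatter), so the two compounds cannot be told apart. Going from 4-fluorophenyl to phenyl therefore shows that, for this pair, the fluoro group is not needed to keep the modest read-out seen at the single concentration tested. Nothing measured here explains why this swap leaves the read-out in place.

Going by these compounds, only fluoro and hydrogen are seen at this position, so it remains open whether a methoxy group or a trifluoromethyl group there would move the read-out beyond the scatter. On these data alone, it is also open how an amide in place of the carboxylic acid on the shared core would read.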